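Propanoyl to vinylcarbonyl on the indolinone series

The source may hold more compounds than are shown below. What is called first, only, known or untested is meant among the compounds shown, and "the series" means these compounds.

Measured compounds:
compound 1 `CCC(=O)Nc1cccc(C(=O)/C=C2/C(=O)Nc3ccccc32)c1` — 7500 nM
compound 2 `O=C1Nc2ccccc2/C1=C\C(=O)c1ccccc1Br` — 9500 nM

In a functional assay on BGC-823 cells (Homo sapiens) for inhibition, read by MTT assay, with a stated time of 72 h (on this read-out lower numbers stand for stronger inhibition and higher numbers for weaker inhibition), compound 1 gives 7500 nM, the lowest of the two numbers in hand. Compound 2, which carries a bromine-substituted aryl ketone in place of the propanoylamino-bearing aryl ketone, gives 9500 nM in this assay; the gap between compound 1 and compound 2 lies within the usual scatter, so neither stands apart from the other.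

Compound 3 `C=CC(=O)Nc1cccc(C(=O)/C=C2/C(=O)Nc3ccccc32)c1` is not yet measured. It differs from compound 1 by vinyl in place of ethyl on a carbonyl carbon; that is, propanoylamino becomes (vinylcarbonyl)amino, with no change in ring count, donors or acceptors.

For the measured compounds named here, no step between measured compounds bears on this change, so only the two values above anchor the expectation. The step is expected to be small, a 1.5-fold lower number from compound 1 to compound 3 (0.18 log units; within the scatter), likely not beyond the scatter in this assay, with a slight lean toward a lower number. Compound 3 is therefore estimated at 5000 nM, within a range of 1500 nM to 15000 nM.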

Compound 3, half-maximal inhibitory concentration: 3600 nM
Beside the measured number, compound 3's estimate is 1.4-fold (0.14 log units) above it; the measured number falls inside the stated range.
By their numbers in this assay, from the lowest: compound 3; then compounds 1 and 2 (each within the scatter of the next).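

In this assay, for the compounds shown here, vinyl in place of ethyl on a carbonyl carbon whose other neighbour is the amide-type nitrogen gives a 2.1-fold lower number from compound 1 to compound 3 (0.32 log units; beyond the scatter) and so provides the first readable step. The two earlier compounds, whose numbers lay within the scatter of each other, could not show whether this position responds to any change at all; it does respond, and to a swap that leaves the heavy-atom count, the ring count and the hydrogen-bond donors and acceptors as they were, adding only a double bond outside the aromatic rings. Nothing at hand accounts for the shift, so the step stands as an observation on one matched pair.

As far as these compounds go, with only ethyl and vinyl seen at this carbonyl carbon, it remains open how the number would move with a longer chain such as butyl, with an alkyne such as ethynyl, or with a vinyl group carrying a dimethylamino substituent. From the compounds shown here alone, it also remains open whether the same swap would give a step of similar size on a different core or with the amide nitrogen substituted, since a single pair cannot establish a trend.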